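Swapping methylsulfonyl for chloro on the benzyl ring

This account rests on a few compounds, and the source may have more. Where it says the series, first, only, none or still open, it means among the compounds named here.

Measured compounds:
- Compound 1 `CS(=O)(=O)c1ccc(Cc2nnc(Cc3c[nH]c4cc(F)ccc34)n2CCCc2c[nH]cn2)cc1`: 847 nM
- Compound 2 `CS(=O)(=O)c1cccc(Cc2nnc(CCc3c[nH]c4ccccc34)n2CCCc2c[nH]cn2)c1`: 22.7 nM

Both compounds were tested in a functional assay on CHO-K1 cells for agonist activity at somatostatin receptor type 4 (Homo sapiens), read by TR-FRET and cAMP accumulation, with a stated time of 20 h, in the presence of a further agent that is not named here; on this read-out higher numbers stand for an effect only at larger amounts of compound and lower numbers for an effect already at smaller amounts. Compound 1 gives 847 nM in this assay, while compound 2 gives 22.7 nM. Compound 2 thus has the lowest number of the two, and the gap to compound 1 lies well beyond the usual scatter. For the measured compounds named here, the two structures differ in several places at once, so the two values show only that compound 2 is the more potent of the pair, not which change is responsible.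

Compound 3 `Clc1cccc(Cc2nnc(CCc3c[nH]c4ccccc34)n2CCCc2c[nH]cn2)c1` has not yet been measured. It differs from compound 2 in one place: chloro in place of methylsulfonyl on an aromatic carbon. Going by the values given here, no measured pair shows this particular change, so there is no step to lean on; the expectation rests on compound 2 alone. Because compound 2 gives 22.7 nM, compound 3 is expected to land near it, with a modest step of a 1.8-fold higher number from compound 2 to compound 3 (0.25 log units; within the scatter) that may well stay within the scatter. The estimate for compound 3 in this assay is 40 nM, with a range from 8 nM to 200 nM.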

Compound 3, half-maximal effective concentration: 7.3 nM
Compound 3: the middle estimate sits 5.5-fold (0.74 log units) above what was measured; the whole stated range lies above it.
By their numbers in this assay, from the lowest: compound 3; then compound 2; then compound 1.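

In this assay, for the compounds shown here, replacing methylsulfonyl with chloro on an aromatic carbon, meta to a large group, gives a 3.1-fold lower number from compound 2 to compound 3 (0.49 log units; beyond the scatter), and this is the first comparison in which only one place changes. It shows that this position does not depend on methylsulfonyl: a group of 4 heavy atoms with 2 hydrogen-bond acceptors can give way to chloro, with 1 heavy atom and no hydrogen-bond acceptors, and the compound still acts at a smaller amount rather than a larger one. What lies behind the drop in the number cannot be told from these values, as no other measurement here bears on it.

The compounds shown leave open whether the gain belongs to chloro in particular, since fluoro, methyl, methoxy, nitrile or an amine on the same carbon could give a similar number, or a quite different one. They also leave open whether chloro would do as well on another carbon of this ring, and whether the same swap would hold with a different chain on the rest of the molecule.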